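Nitro in place of trifluoromethyl on the benzoyl hydrazone

A few compounds are considered here, and "the series" means these few. Any claim that something is new, unique, unknown or untested is made for them only; others in the source may bear on it.

Measured so far in a functional assay for inhibition, read by spectrophotometry, with a stated time of 120 min; a higher number here means a weaker inhibitor, a lower number a stronger inhibitor:
compound 1 `O=C(NN=C1CC(c2ccccc2)NC(c2ccccc2)C1)c1ccc(Cl)cc1` gives 43600 nM;
compound 2 `O=C(NN=C1CC(c2ccccc2)NC(c2ccccc2)C1)c1ccc(F)cc1` gives 56600 nM;
compound 3 `O=C(NN=C1CC(c2ccccc2)NC(c2ccccc2)C1)c1ccc(C(F)(F)F)cc1` gives 55300 nM.

All three share one core and differ only in the group that sits on an aromatic carbon, para to a large group. On the numbers shown, compound 3 stands second highest of the three, but its nearest neighbour is compound 2, with a 1.0-fold lower number from compound 2 to compound 3 (0.01 log units; within the scatter), and its furthest is compound 1, with a 1.3-fold higher number from compound 1 to compound 3 (0.10 log units; within the scatter). Both of these steps lie within the scatter, so the three values cannot be told apart.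

Compound 4 `O=C(NN=C1CC(c2ccccc2)NC(c2ccccc2)C1)c1ccc([N+](=O)[O-])cc1` takes the same core and makes one more swap at that position: nitro in place of trifluoromethyl on an aromatic carbon. The three measured steps that bear on this change are all exchanges of one group for another at the same place: a 1.3-fold higher number from compound 1 to compound 2 (0.11 log units; within the scatter), a 1.3-fold higher number from compound 1 to compound 3 (0.10 log units; within the scatter) and a 1.0-fold lower number from compound 2 to compound 3 (0.01 log units; within the scatter). None of them moved the number beyond the scatter. On that record, the expected step in this assay is a 1.1-fold lower number from compound 3 to compound 4 (0.04 log units; within the scatter), which is to say no change that the assay could resolve. Compound 4 is therefore estimated to give 50000 nM, with a range from 25000 nM to 100000 nM.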

Compound 4, half-maximal inhibitory concentration: 45200 nM
For compound 4 the middle estimate is 1.1-fold (0.04 log units) above the measured one; low and high end bracket the measured number.
By their numbers in this assay, from the lowest: compounds 1, 4, 3 and 2 (each within the scatter of the next).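

In this assay the nitro group leaves the reading unresolved from those of the other three groups, with a 1.2-fold lower number from compound 3 to compound 4 (0.09 log units; within the scatter) for the exchange with trifluoromethyl and a 1.3-fold lower number from compound 2 to compound 4 (0.10 log units; within the scatter) for the exchange with fluoro and a 1.0-fold higher number from compound 1 to compound 4 (0.02 log units; within the scatter) for the exchange with chloro. The earlier compounds shown here compared only chloro, fluoro and trifluoromethyl, whereas nitro brings nitrogen and oxygen to this aromatic carbon and is counted with hydrogen-bond acceptors, which trifluoromethyl is not. Even this different kind of group gives no step the assay can resolve, so all four compounds now read as one group of values, and nothing measured here explains why they read alike.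

As far as these compounds go, whether any group at this place can move the number beyond the scatter remains open, as an amine, a carboxylic acid, a hydroxyl, a longer chain or a plain hydrogen on the same aromatic carbon could still behave differently. The compounds shown also leave open what changes elsewhere on the shared core would do to the number.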